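Methyl on the Oxygen of Compound 2

This account rests on a few compounds, and the source may have more. Where it says the series, first, only, none or still open, it means among the compounds named here.

In a functional assay on a cell-free system (plasma, Oryctolagus cuniculus) for inhibition, with stated times of 5 min, 1 min and 6 min (on this read-out higher numbers stand for weaker inhibition and lower numbers for stronger inhibition), compound 1 (`CCOC(=O)c1c(C)nc(-c2ccc(OCC(C)C)c(C#N)c2)n1O`) gives 16800 nM and compound 2 (`CCOC(=O)c1c(C)nc(-c2cccc(C#N)c2)n1O`) gives 17600 nM as its reading, so compound 2 stands level with compound 1 within the scatter. Going by the values given here, the only measured step, a 1.0-fold higher number from compound 1 to compound 2 (0.02 log units; within the scatter) with hydrogen in place of isobutoxy on an aromatic carbon, lies within the scatter. Compound 3 (`CCOC(=O)c1c(C)nc(-c2cccc(C#N)c2)n1OC`) departs from compound 2 elsewhere: methyl in place of hydrogen on an oxygen on an aromatic ring with methyl in place of hydrogen on an oxygen on an aromatic ring, hydroxy to methoxy. Among the compounds with values here, the measured step sits at a different place, and no measured pair alters this oxygen, so the data give only weak guidance. A moderate move to a higher number is expected, though a result within the scatter remains possible. The expected size is a 2.3-fold higher number from compound 2 to compound 3 (0.36 log units; beyond the scatter) in this estimate. In this assay the estimate for compound 3 is 40000 nM with an expected range from 12000 nM to 130000 nM as its likely span.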

Compound 3, half-maximal inhibitory concentration: 9130 nM
The estimate for compound 3 lay 4.4-fold (0.64 log units) above the measured number; measured number outside the range, below it.
By their numbers in this assay, from the lowest: compounds 3, 1 and 2 (each within the scatter of the next).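

At this oxygen, the first change measured at this position, a 1.9-fold lower number from compound 2 to compound 3 (0.29 log units; within the scatter) in this assay. Hydroxy to methoxy therefore leaves the reading level with that of compound 2, so the hydrogen on this oxygen can give way to methyl without a measurable loss of inhibition, and the change at this oxygen proves as silent as the earlier exchange of isobutoxy for hydrogen on an aromatic carbon. Nothing available explains this tolerance of methyl on the oxygen.

The compounds shown leave open whether a larger group on this oxygen, such as a propyl chain or a benzyl group, would move the reading beyond the scatter. They also do not show whether methoxy and isobutoxy together would read the same as either one alone.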